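The source may report more compounds than this note shows. Statements on the series, on what has been measured and on what is new or still open speak of the compounds shown alone.

Measured so far:
compound 1, `CN(C)CCNc1nc(-c2ccc(NC(=O)Nc3ccccc3)cc2)nc2ccsc12`, gives 620 nM in a functional assay on HT-29 cells (Homo sapiens) for cytotoxicity, read by MTT assay, with a stated time of 72 h; a lower number here means a stronger inhibitor, a higher number a weaker inhibitor
compound 2, `CN(C)CCNc1nc(-c2ccc(NC(=O)Nc3ccc(F)cc3)cc2)nc2ccsc12`, gives 350 nM in this assay
compound 3, `CN(C)CCNc1nc(-c2ccc(NC(=O)Nc3ccccc3F)cc2)nc2ccsc12`, gives 510 nM in this assay

All three compounds share one core and differ only in the ring carried on the amide-type nitrogen. Among the three numbers, compound 3 gives the second highest; its nearest neighbour is compound 1, with a 1.2-fold lower number from compound 1 to compound 3 (0.08 log units; within the scatter), and its furthest is compound 2, with a 1.5-fold higher number from compound 2 to compound 3 (0.16 log units; within the scatter). Both gaps lie within the scatter, so the three compounds cannot be ranked on these data.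

Compound 4, `CN(C)CCNc1nc(-c2ccc(NC(=O)Nc3ccc(Cl)cc3)cc2)nc2ccsc12`, is the next step: 4-chlorophenyl in place of 2-fluorophenyl on an amide-type nitrogen. For the measured compounds named here, two measured steps bear on it. The step of a 1.5-fold higher number from compound 2 to compound 3 (0.16 log units; within the scatter) shows that moving the fluorine between the 4-fluorophenyl and the 2-fluorophenyl made no difference beyond the scatter. The step of a 1.8-fold lower number from compound 1 to compound 2 (0.25 log units; within the scatter) shows that adding a fluorine to give the 4-fluorophenyl also stayed within the scatter. Going by the values given here, no measured step swaps fluorine for chlorine, so that part of the change is untested. The expected step in this assay is therefore small, a 1.5-fold lower number from compound 3 to compound 4 (0.19 log units; within the scatter), leaning if anything toward a lower number, as seen for compound 2 with 350 nM. Compound 4 is estimated at 330 nM, with a range from 140 nM to 800 nM.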

Compound 4, half-maximal inhibitory concentration: 95 nM
Estimate against measurement, compound 4: 3.5-fold (0.54 log units) above; the measured number lies below the stated range.
By their numbers in this assay, from the lowest: compound 4; then compounds 2, 3 and 1 (each within the scatter of the next).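

For the compounds shown here, until this result, every change on the ring carried by the amide-type nitrogen stayed within the scatter, so the position looked insensitive; in this assay the step of chloro in place of fluoro on an aromatic carbon is the first here to stand clear of that scatter, with a 3.7-fold lower number from compound 2 to compound 4 (0.57 log units; beyond the scatter) at this position. The choice of atom matters here: fluoro in place of hydrogen gave only a 1.8-fold lower number from compound 1 to compound 2 (0.25 log units; within the scatter), whereas chloro in place of hydrogen gives a 6.5-fold lower number from compound 1 to compound 4 (0.81 log units; beyond the scatter) on the same parent. Going from 2-fluorophenyl to 4-chlorophenyl gives a 5.4-fold lower number from compound 3 to compound 4 (0.73 log units; beyond the scatter) and makes compound 4 the strongest inhibitor of the four, although that step changes both the atom and the group's name, so it cannot show how much each contributes.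

No measurement shown here explains why chloro and fluoro differ in this assay. The compounds shown also leave open whether the lower number belongs to chloro alone or would also appear with bromo, methyl or trifluoromethyl in its place.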